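The compounds below may be only part of what the source reports. "The series", "measured", "known", "first", "only" and "open" are said of these compounds alone.

Measured so far in a functional assay on A549 cells (Homo sapiens) for antiproliferative activity, read by MTT assay, with a stated time of 24 h; a lower number here means a stronger inhibitor, a higher number a weaker inhibitor:
- compound 1 `Cc1ccc(-c2nn(-c3ccccc3)cc2-c2nc3ccccc3n2S(=O)(=O)c2ccccc2)cc1`: 760 nM
- compound 2 `Cc1ccc(-c2nn(-c3ccccc3)cc2-c2nc3ccccc3n2S(=O)(=O)c2cc(C)ccc2C)cc1`: 270 nM

Of these two, compound 2 has the lower number at 270 nM, and its gap to compound 1 lies beyond the scatter. The next compound is compound 3 `Cc1ccc(-c2nn(-c3ccccc3)cc2-c2nc3ccccc3n2S(=O)(=O)c2ccc(F)cc2)cc1`, which differs from compound 2 as follows: 4-fluorophenyl in place of 2,5-dimethylphenyl on a sulfonyl sulfur. In other words, it has 4-fluorophenyl in place of 2,5-dimethylphenyl on a sulfonyl sulfur.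

Going by the values given here, only one measured step bears on this change: a 2.8-fold lower number from compound 1 to compound 2 (0.45 log units; beyond the scatter). This modest step came with 2,5-dimethylphenyl in place of phenyl on the same sulfonyl sulfur. Among the compounds with values here, compound 3 gives up that 2,5-dimethylphenyl, while no measured compound carries 4-fluorophenyl, so the data leave its contribution open. Within the data shown here, a modest move to a higher number in this assay is therefore expected, no larger than the step already seen. The estimated step is a 1.9-fold higher number from compound 2 to compound 3 (0.27 log units; within the scatter). The expected value for compound 3 is 500 nM, with an estimated range from 190 nM to 1300 nM.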

Compound 3, half-maximal inhibitory concentration: 3240 nM
Beside the measured number, compound 3's estimate is 6.5-fold (0.81 log units) below it; measured number outside the range, above it.
By their numbers in this assay, from the lowest: compound 2; then compound 1; then compound 3.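

In this assay, the group on the sulfonyl sulfur proves able to move the number in either direction: with fluoro in place of hydrogen on an aromatic carbon, the result is a 4.3-fold higher number from compound 1 to compound 3 (0.63 log units; beyond the scatter) and not the fall that the earlier pair alone had shown. The two changes therefore pull apart from the phenyl of compound 1, and exchanging 2,5-dimethylphenyl for 4-fluorophenyl gives a 12-fold higher number from compound 2 to compound 3 (1.08 log units; beyond the scatter), a large step and the widest gap among the three compounds, all of which differ on this one group. Nothing measured here accounts for this difference between the two groups.

The compounds shown leave open which of the two methyl groups in 2,5-dimethylphenyl goes with the lower number of compound 2, and whether fluoro would give the same rise elsewhere on the phenyl ring. They also leave open how chloro, methoxy, an amine or a carboxylic acid on that ring would read in this assay, and whether a simple methyl on the sulfonyl sulfur could stand in for the aromatic ring.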